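The source may report more compounds than this note shows. Statements on the series, on what has been measured and on what is new or still open speak of the compounds shown alone.

Compound 1 `C=C(Br)C(=O)Nc1ccc(/C=C/C(=O)c2ccc(F)cc2)cc1`: 1200 nM
Compound 2 `C=C(Br)C(=O)Nc1ccc(/C=C/C(=O)c2ccc(Br)cc2)cc1`: 1100 nM
Compound 3 `C=C(Br)C(=O)Nc1ccc(/C=C/C(=O)c2ccc(I)cc2)cc1`: 8300 nM

In a functional assay on FM3A cells (Mus musculus) for antiproliferative activity, with a stated time of 48 h (a higher number here means a weaker inhibitor, a lower number a stronger inhibitor), compound 3 is the weakest of the three, at 8300 nM. Compound 4 `C=C(Br)C(=O)Nc1ccc(/C=C/C(=O)c2ccc(OCC)cc2)cc1` carries ethoxy in place of iodo on an aromatic carbon. Only the halogen swaps bear on this change, and none of them involves ethoxy. The swap from bromo to fluoro's neighbour aside, a 1.1-fold lower number from compound 1 to compound 2 (0.04 log units; within the scatter), which stays within the scatter, the two steps to iodo are modest: a 6.9-fold higher number from compound 1 to compound 3 (0.84 log units; beyond the scatter) and a 7.5-fold higher number from compound 2 to compound 3 (0.88 log units; beyond the scatter). Compound 3 thus stands apart, so a modest move towards a lower number is expected in this assay, though with much uncertainty. The estimate means a 2.8-fold lower number from compound 3 to compound 4 (0.44 log units; beyond the scatter). For compound 4 the expected value is 3000 nM, with an estimated range of 900 nM to 10000 nM.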

Compound 4, half-maximal inhibitory concentration: 680 nM
For compound 4 the middle estimate is 4.4-fold (0.64 log units) above the measured one, and the stated range ends above it.
By their numbers in this assay, from the lowest: compounds 4, 2 and 1 (each within the scatter of the next); then compound 3.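

In this assay, the step from iodo to ethoxy at this position, para to a large group, is large, with a 12-fold lower number from compound 3 to compound 4 (1.09 log units; beyond the scatter), so a group of more heavy atoms than iodo can sit here without the loss seen with iodo. Ethoxy also stands level with bromo and fluoro, with a 1.6-fold lower number from compound 2 to compound 4 (0.21 log units; within the scatter) and a 1.8-fold lower number from compound 1 to compound 4 (0.25 log units; within the scatter), both within the scatter, which leaves iodo alone among the four. Nothing measured here explains why iodo stands apart. The compounds shown leave open whether a longer alkoxy chain, an amine or a carboxylic acid would stay level with ethoxy at this position.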